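This account rests on a few compounds, and the source may have more. Where it says the series, first, only, none or still open, it means among the compounds named here.

Compound 1, `COc1ccc(-c2cn(C[C@H]3c4c(ccc(O)c4C)[C@@H]4CC[C@@]5(C)C[C@]43CC5=O)nn2)cc1`: in a functional assay on SMMC-7721 cells (Homo sapiens) for cytotoxicity, read by MTT assay, with a stated time of 4 days (a higher number here means a weaker inhibitor, a lower number a stronger inhibitor), compound 1 gives > 20000 nM, a limit of the assay rather than a number.
Compound 2, `C=C1C[C@]23C[C@@]1(O)CC[C@@H]2c1cccc(C)c1[C@@H]3Cn1cc(-c2ccc(Br)cc2)nn1`: compound 2 gives > 20000 nM, again only a limit.
Compound 3, `C=C1C[C@]23C[C@@]1(O)CC[C@H]2c1cc(Br)c(O)c(C)c1[C@@H]3Cn1cc(-c2ccc(C)cc2)nn1`: compound 3 gives > 20000 nM, also a limit and not a number.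

Compound 3 thus stands where the other two measured compounds stand: at the boundary of what this assay reports, with no number to rank it against them. Among the compounds with values here, the three values show only that none of the compounds reached the range in which a half-maximal inhibitory concentration could be read, as summarised by the limit of > 20000 nM in this assay, at which 3 of the 3 values shown sit.

Compound 4, `C=C1C[C@]23C[C@@]1(O)CC[C@H]2c1cc(Br)c(O)c(C)c1[C@@H]3Cn1cc(-c2ccccn2)nn1`, has not yet been measured in this assay. It differs from compound 3 in one place: pyridin-2-yl in place of 4-methylphenyl on an aromatic carbon. Within the data shown here, no step between measured compounds is available, so the size of this change cannot be read from them; the earlier compounds give no guidance on how a change at that carbon moves the value, because all of them sit at the limit of > 20000 nM in this assay, at which 3 of the 3 values shown sit. Compound 4 is expected to give 25000 nM, in the range 8000 nM to 60000 nM, most probably again as a limit. The step this estimate means, a step that the limit leaves unreadable from compound 3 to compound 4, is expected to be none beyond the scatter.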

Compound 4, half-maximal inhibitory concentration: > 20000 nM
Compound 4 ended at the assay's limit (the forecaster's own chance of this, stated with the estimate: 75%); the middle value is on the limit's open side.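

Pyridin-2-yl in place of 4-methylphenyl yields no step that can be read between compound 3 and compound 4, because both compounds sit at the assay's limit: the limit of > 20000 nM in this assay, at which 4 of the 4 values shown sit.

The compounds shown leave open whether any change, at that carbon or elsewhere on the shared core, would give a number rather than a limit.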